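A few compounds are considered here, and "the series" means these few. Any claim that something is new, unique, unknown or untested is made for them only; others in the source may bear on it.

Of the compounds shown here, two have been measured in a functional assay on the whole organism with Rattus norvegicus as the target, read by spectrophotometry, with stated times of 14 days and 3 days, at a dose of 10 mg/kg by the oral route; a lower number here means less inhibition, a higher number more inhibition at the dose given (going by the name of the read-out). Compound 1 `O=C1c2c(Cl)c(Cl)c(Cl)c(Cl)c2C(=O)N1Cc1ccccn1` gives 23%, and compound 2 `O=C1c2cc(Cl)c(Cl)cc2C(=O)N1c1ccccn1` gives 3%. Compound 1 therefore stands highest of the two numbers, and its nearest neighbour, compound 2, lies lower by a gap that exceeds the usual scatter. Among the compounds with values here, the two differ in more than one place, so no single step connects them.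

Compound 3 `O=C1c2c(Cl)c(Cl)c(Cl)c(Cl)c2C(=O)N1c1ncccn1` is the next to be measured in this assay. It differs from compound 1 as follows: pyrimidin-2-yl in place of (pyridin-2-yl)methyl on an amide-type nitrogen in a ring. Within the data shown here, no measured pair shows this change alone. Going only by the low reading of compound 2, which also carries its aromatic ring directly on the amide-type nitrogen, a downward step is expected from compound 1 to compound 3, estimated at a number 11 percentage points lower from compound 1 to compound 3 (beyond the scatter), though it may stay within the scatter. Compound 3 is accordingly expected to give about 12% in this assay, within a range of 0% to 30%.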

Compound 3, a percentage reported as inhibition, in the whole organism at one dose (the size of the read-out at that dose, not a potency): 5%
For compound 3 the middle estimate is 7 percentage points above the measured one; measured number inside the range.
By their numbers in this assay, from the lowest: compounds 2 and 3 (each within the scatter of the next); then compound 1.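

In this assay, the group on the amide-type nitrogen in a ring can now be judged alone: with the rest of compound 1 unchanged, pyrimidin-2-yl in place of (pyridin-2-yl)methyl gives a number 18 percentage points lower from compound 1 to compound 3 (beyond the scatter), so the read-out depends on the group at this position. The change replaces the ring and removes the methyl link in a single step, so this result cannot separate the contribution of one from the other. No measurement shown here accounts for the step.

The compounds shown leave open whether (pyrimidin-2-yl)methyl on this nitrogen would keep the reading of compound 1, which would isolate the effect of the ring. They also leave open how an open-chain group, such as a longer alkyl chain ending in an amine or a carboxylic acid, would read at this position.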